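A Sulfonyl Swap Among Compounds Held at Assay Limits

The source may hold more compounds than are shown below. What is called first, only, known or untested is meant among the compounds shown, and "the series" means these compounds.

Measured in an ADME assay on HCT-116 cells (Homo sapiens) for cytotoxicity, read by CellTiter-Glo, with a stated time of 72 h (on this read-out higher numbers stand for weaker inhibition and lower numbers for stronger inhibition), where all three results are limits and not numbers:
- Compound 1 `Cc1cc(C)c(S(=O)(=O)N2CCN(C3CN4CCC3CC4)CC2)c(C)c1`: > 5000 nM
- Compound 2 `Cc1noc(C)c1S(=O)(=O)N1CCC(N2CCC(C)CC2)CC1`: > 10000 nM
- Compound 3 `Cc1ccc(-c2ccccc2S(=O)(=O)N2CCC(N3CCC(C)CC3)CC2)cc1`: > 5000 nM

Compound 2 stands at the limit of > 10000 nM in this assay, at which 1 of the 3 values shown sits, and this is a limit. Compound 1 and compound 3 share (the limit of > 5000 nM in this assay, at which 2 of the 3 values shown sit), which is also a limit. For the measured compounds named here, no measured compound in the set therefore gives a number, and no pair of them differs in one place alone, so the data offer no measured step to serve as a guide.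

Compound 4 `CC1CCN(C2CCN(S(=O)(=O)c3cccnc3Cl)CC2)CC1` carries 2-chloropyridin-3-yl in place of 3,5-dimethyl-1,2-oxazol-4-yl on a sulfonyl sulfur. The expectation rests on compound 2 with its limit of > 10000 nM. Expected here is a number no higher from compound 2 to compound 4 (the limit leaves the size open), with nothing beyond the usual scatter in either direction. A limit is also the likely report. For compound 4 the estimated value in this assay is 10000 nM, with an expected range from 3500 nM to 25000 nM.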

Compound 4, half-maximal inhibitory concentration: > 10000 nM
Compound 4 ended at the assay's limit; the forecaster's own chance of this, stated with the estimate: 85%; the middle value sits exactly at the limit.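

In this assay, for the compounds shown here, compound 2 and compound 4 both end at a limit, so 2-chloropyridin-3-yl in place of 3,5-dimethyl-1,2-oxazol-4-yl gives no step that can be read. The compounds shown leave open how strongly any of them inhibits: all four results are limits, not numbers.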